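N-Demethylation of the Fused Core: Solubility Working Notes

This account rests on a few compounds, and the source may have more. Where it says the series, first, only, none or still open, it means among the compounds named here.

Measured compounds and their values:
compound 1, `Cn1ncc2c(NC3(c4ccc(C(F)(F)F)cc4)CC3)nc(Cl)nc21`: 156000 nM
compound 2, `Cn1ncc2c(NCc3ccc(C(F)(F)F)cc3)nc(Cl)nc21`: 164000 nM

In a physicochemical assay for solubility, at pH 6.5 (on this read-out lower numbers stand for lower solubility and higher numbers for higher solubility), compound 1 gives 156000 nM, the lowest of the two numbers obtained so far. Compound 2 gives 164000 nM in this assay, and the gap between compound 2 and compound 1 lies within the usual scatter, so the two values cannot be ranked against each other. Among the measured compounds shown here, no pair of measured compounds differing in a single place is available, so no measured step exists to anchor an expectation.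

Compound 3, `FC(F)(F)c1ccc(C2(Nc3nc(Cl)nc4[nH]ncc34)CC2)cc1`, has not yet been measured in this assay. It differs from compound 1 in one place: hydrogen in place of methyl on an aromatic nitrogen. Since nothing measured here speaks to this change, the expectation for compound 3 rests on compound 1 alone, with 156000 nM as the reference point. The step of a 1.2-fold higher number from compound 1 to compound 3 (0.06 log units; within the scatter) is expected to be small and not clearly beyond the scatter. Compound 3 is accordingly estimated at 180000 nM in this assay, within a range from 60000 nM to 500000 nM.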

Compound 3, solubility: 105000 nM
Beside the measured number, compound 3's estimate is 1.7-fold (0.23 log units) above it, and the stated range covers the measured number.
By their numbers in this assay, from the lowest: compounds 3, 1 and 2 (each within the scatter of the next).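

Swapping methyl for hydrogen on an aromatic nitrogen of the five-membered aromatic ring gives the first single-place step in this series: in this assay, the change is a 1.5-fold lower number from compound 1 to compound 3 (0.17 log units; within the scatter). This step shows that, with the side chain of compound 1 held constant, taking the methyl off this nitrogen and leaving a hydrogen there produces no difference in the read-out that can be told apart from the scatter, so the methyl is not shown to matter for this read-out at this position. Nothing available bears on why the values of this pair sit as they do.

The compounds shown leave open whether a larger group on the same nitrogen, such as an ethyl, a longer chain or a chain ending in a carboxylic acid or an amine, would move the read-out beyond the scatter. Among the compounds shown here, they also leave open whether hydrogen in place of methyl would give a similar step on the side chain of compound 2, as no pair with that side chain differs at this nitrogen.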